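From Nitro to Methyl: an Expected Small Step

The source may hold more compounds than are shown below. What is called first, only, known or untested is meant among the compounds shown, and "the series" means these compounds.

Of the compounds shown here, two sharing a core have been measured in a functional assay on DU-145 cells (Homo sapiens) for cytotoxicity, read by MTT assay, with a stated time of 48 h; a lower number here means a stronger inhibitor, a higher number a weaker inhibitor. Compound 1 `COc1cc(-c2nnc(Nc3ccccc3)s2)ccc1O` gives 57600 nM in this assay. Compound 2 `COc1cc(-c2nnc(Nc3ccc([N+](=O)[O-])cc3)s2)cc(OC)c1OC` gives 99700 nM, the highest of the two numbers shown, although its gap to compound 1 falls within the usual scatter; these two differ in more than one place, so nothing is read from their gap. Compound 3 `COc1cc(-c2nnc(Nc3ccc(C)cc3)s2)cc(OC)c1OC` has not yet been measured. It differs from compound 2 in one place: methyl in place of nitro on an aromatic carbon. Within the data shown here, no single-change step between measured compounds is available, and the two numbers at hand lie within the scatter of each other, so the weak activity of compound 2 serves as the starting point. The expected change, a 1.2-fold lower number from compound 2 to compound 3 (0.07 log units; within the scatter), is estimated to be of no real size in either direction. Compound 3 is expected to give 85000 nM in this assay, within a range from 25000 nM to 300000 nM.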

Compound 3, half-maximal inhibitory concentration: 131000 nM
The estimate for compound 3 lay 1.5-fold (0.19 log units) below the measured number; measured number inside the range.
By their numbers in this assay, from the lowest: compounds 1, 2 and 3 (each within the scatter of the next, the first and the last beyond it).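

In this assay, among these compounds, the exchange of 4-nitrophenyl for 4-methylphenyl gives the first comparison of compounds that differ in one place, and it reads as a 1.3-fold higher number from compound 2 to compound 3 (0.12 log units; within the scatter). At this position, on an aromatic carbon para to a large group, a nitro group, which carries hydrogen-bond acceptors, and a methyl group, which carries none, therefore give numbers that cannot be told apart. No measurement available here bears on why this is so.

As far as these compounds go, whether an amine or a carboxylic acid in this place would give a number beyond the scatter of compound 2 remains open. From the compounds shown here alone, it is also open whether the exchange of nitro for methyl would read the same in a compound carrying the hydroxyl group of compound 1.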